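This account rests on a few compounds, and the source may have more. Where it says the series, first, only, none or still open, it means among the compounds named here.

Compound 1 `N#CC1=C(N)OC(c2c[nH]c3ccccc23)=C(C#N)C1c1ccc(Br)cc1` gives in a functional assay on MCF7 cells (Homo sapiens) for cytotoxicity, read by MTT assay, with a stated time of 24 h (on this read-out lower numbers stand for higher toxicity in this test and higher numbers for lower toxicity in this test), the value > 100000 nM, which is a limit of the assay.
Compound 2 `N#CC1=C(N)OC(c2c[nH]c3ccccc23)=C(C#N)C1c1ccc2ccccc2c1` gives in this assay the value 91500 nM.
Compound 3 `N#CC1=C(N)OC(c2c[nH]c3ccccc23)=C(C#N)C1c1ccc(F)cc1` gives in this assay the value > 100000 nM, again a limit of the assay.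

Compound 3 thus stands only at a limit, as the limit of > 100000 nM in this assay, at which 2 of the 3 values shown sit, shows. Compound 4 `N#CC1=C(N)OC(c2c[nH]c3ccccc23)=C(C#N)C1c1cccc2ccccc12` differs from it by naphthalen-1-yl in place of 4-fluorophenyl on a saturated ring carbon. Among the measured compounds shown here, two measured steps bear on this kind of swap: the step of an at least 1.0-fold lower number from compound 1 to compound 2 (0.03 log units; that floor lies within the scatter) and the step of an at least 1.0-fold higher number from compound 2 to compound 3 (0.03 log units; that floor lies within the scatter), each readable only as a floor inside the scatter, while the step that the two limits leave unreadable from compound 1 to compound 3 cannot be read at all. No step beyond the scatter is therefore expected in this assay from compound 3 to compound 4, and either a number near that of compound 2 or a further limit seems plausible. Compound 4 is estimated at 95000 nM, within 50000 nM to 200000 nM. That expectation amounts to an at least 1.0-fold lower number from compound 3 to compound 4 (0.02 log units; that floor lies within the scatter).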

Compound 4, concentration lethal to 50% of the cells: 80200 nM
Compound 4: middle estimate off by 1.2-fold (0.07 log units), on the high side; the range from low to high includes it.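

In this assay, naphthalen-1-yl on this saturated ring carbon gives a measured number rather than a limit, so it can be compared directly with naphthalen-2-yl at the same place: a 1.1-fold lower number from compound 2 to compound 4 (0.06 log units; within the scatter). Against 4-fluorophenyl and 4-bromophenyl, only floors can be read, an at least 1.2-fold lower number from compound 3 to compound 4 (0.09 log units; that floor lies within the scatter) and an at least 1.2-fold lower number from compound 1 to compound 4 (0.09 log units; that floor lies within the scatter), so the true size of these steps stays unknown: the limit of > 100000 nM in this assay, at which 2 of the 4 values shown sit.

The compounds shown leave open whether an amine or a carboxylic acid on the aromatic group at this carbon would give a step beyond the scatter.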